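A few compounds are considered here, and "the series" means these few. Any claim that something is new, unique, unknown or untested is made for them only; others in the source may bear on it.

Series notes. Compound 1 `CO[C@H]1CC=C2CCN(C)[C@H]2C1` gives 100000 nM in an assay on HEK293 cells for displacement of a labelled ligand from Neuronal acetylcholine receptor; alpha4/beta4 (Rattus norvegicus), with a stated time of 4 h; on this read-out lower numbers stand for stronger inhibition and higher numbers for weaker inhibition. Compound 2 `COCCO[C@H]1CC=C2CCN(C)[C@H]2C1` gives > 300000 nM in this assay, and this is a limit of the assay, not a number. Compound 2 thus stands at the limit of > 300000 nM in this assay, at which 1 of the 2 values shown sits. Among the measured compounds shown here, the only measured comparison is the step of an at least 3.0-fold higher number from compound 1 to compound 2 (0.47 log units; beyond the scatter), which raised the number. Compound 3 `CN1CCC2=CC[C@H](O)C[C@@H]21` differs from compound 2 by hydrogen in place of 2-methoxyethyl on an oxygen on a saturated carbon. That change runs counter to the measured step, so a lower number is expected, with the expected step being an at least 3.0-fold lower number from compound 2 to compound 3 (0.47 log units; beyond the scatter). Compound 3 is therefore estimated at 100000 nM, within a range from 20000 nM to 300000 nM.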

Compound 3, inhibition constant: > 300000 nM
Compound 3 gave a limit, no number (the forecaster's own chance of this, stated with the estimate: 35%); at least 3.0-fold (0.47 log units) between middle value and limit.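

In this assay, hydrogen in place of methyl on this oxygen gives an at least 3.0-fold higher number from compound 1 to compound 3 (0.47 log units; beyond the scatter). Compound 3 gives > 300000 nM, which is a limit of the assay, and the step to it from compound 2 cannot be read. Of hydrogen, methyl and 2-methoxyethyl on this oxygen, only methyl gives a number rather than a limit, so both the removal and the lengthening of methyl raise the number: the limit of > 300000 nM in this assay, at which 2 of the 3 values shown sit.

Going by these compounds, the order of compound 2 and compound 3 stays open. So does whether an amine or a carboxylic acid on this oxygen would give a number lower than that of compound 1.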